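The source may report more compounds than this note shows. Statements on the series, on what has been measured and on what is new or still open speak of the compounds shown alone.

In an assay on frontal cortex for displacement of a labelled ligand from corticotropin-releasing factor receptor 1 (Rattus norvegicus), with a stated time of 2 h (on this read-out lower numbers stand for stronger inhibition and higher numbers for weaker inhibition), compound 3 `COc1nc(C)c(Nc2nc(Cl)cn([C@H](COc3ccccn3)C3CC3)c2=O)cc1C` gives 1.2 nM, the lowest of the three numbers; compound 1 `COc1nc(C)c(Nc2nc(Cl)cn([C@H](COC(=O)c3cccnc3)C3CC3)c2=O)cc1C` gives 5.2 nM and compound 2 `COc1ccc(NC(=O)OC[C@H](C2CC2)n2cc(Cl)nc(Nc3cc(C)c(OC)nc3C)c2=O)c(C)n1` gives 9.2 nM, with a 4.3-fold lower number from compound 1 to compound 3 (0.64 log units; beyond the scatter) and a 7.7-fold lower number from compound 2 to compound 3 (0.88 log units; beyond the scatter) both reaching beyond the scatter. Compound 4 `COc1nc(C)c(Nc2nc(Cl)cn([C@H](COc3ccc(C(F)(F)F)cn3)C3CC3)c2=O)cc1C` differs from compound 3 by trifluoromethyl in place of hydrogen on an aromatic carbon. Neither measured step touches that ring position: each replaced the whole group on the oxygen, and a 1.8-fold higher number from compound 1 to compound 2 (0.25 log units; within the scatter) stayed within the scatter. Within the data shown here, no step therefore bears directly on this change, and in this assay a step from compound 3 to compound 4 of no more than the scatter is expected, a 1.3-fold higher number from compound 3 to compound 4 (0.10 log units; within the scatter). Compound 4 is estimated at 1.5 nM, between 0.5 nM and 5 nM.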

Compound 4, half-maximal inhibitory concentration: 1.6 nM
Compound 4: middle estimate off by 1.1-fold (0.03 log units), on the low side; low and high end bracket the measured number.
By their numbers in this assay, from the lowest: compounds 3 and 4 (each within the scatter of the next); then compounds 1 and 2 (each within the scatter of the next).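

In the ring attached through the oxygen, trifluoromethyl can occupy the aromatic carbon two atoms from the ring nitrogen without a readable change in this assay (a 1.3-fold higher number from compound 3 to compound 4 (0.12 log units; within the scatter)). The 5-(trifluoromethyl)pyridin-2-yl group also retains the advantage of the unsubstituted pyridin-2-yl group over the two larger groups on that oxygen (a 3.3-fold lower number from compound 1 to compound 4 (0.51 log units; beyond the scatter); a 5.8-fold lower number from compound 2 to compound 4 (0.76 log units; beyond the scatter)). No measurement shown explains these results.

As far as these compounds go, it remains open whether a nitrile, an amine or a carboxylic acid at this carbon would also leave the number unchanged. The effect of trifluoromethyl on other carbons of this ring is also unknown.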